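Cycloheptyl in place of cyclopentyl on compound 3

This account rests on a few compounds, and the source may have more. Where it says the series, first, only, none or still open, it means among the compounds named here.

Among the measured compounds shown here, in a functional assay on PC-3 cells (Homo sapiens) for cytotoxicity, read by WST assay, with a stated time of 72 h (on this read-out lower numbers stand for stronger inhibition and higher numbers for weaker inhibition), compound 3 (`COc1ccc2c(c1C)NC(=O)C2(c1ccc(O)cc1)C1CCCC1`) gives 111 nM as the only number so far. Compound 1 (`Cc1cccc2c1NC(=O)C2(c1ccc(O)cc1)C1CCCCCC1`) reads > 1000 nM as a limit of the assay. Compound 2 (`Cc1ccc2c(c1C)NC(=O)C2(c1ccc(O)cc1)C1CCCCCC1`) reads > 1000 nM as a limit too.

The next change leads to compound 4 (`COc1ccc2c(c1C)NC(=O)C2(c1ccc(O)cc1)C1CCCCCC1`) and places cycloheptyl in place of cyclopentyl on a saturated ring carbon. For the measured compounds named here, the only measured step (a step that the two limits leave unreadable from compound 1 to compound 2) concerns methyl in place of hydrogen on an aromatic carbon, so it offers no size to carry over. Some weakening in this assay is expected because the limit of > 1000 nM in this assay, at which 2 of the 3 values shown sit, and those two values belong to compound 1 and compound 2, which both carry cycloheptyl. Neither limit fixes the size of the change, so only a moderate rise is assumed. The expected change is a rise in the number (a 2.3-fold higher number from compound 3 to compound 4 (0.35 log units; beyond the scatter)). The estimate for compound 4 is 250 nM (expected range 60 nM to 1000 nM).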

Compound 4, half-maximal inhibitory concentration: 12 nM
Estimate against measurement, compound 4: 21-fold (1.32 log units) above; measured number outside the range, below it.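

In this assay, cycloheptyl on this saturated ring carbon does not by itself go with weak inhibition, since with methoxy on the aromatic carbon the larger ring gives a lower number (a 9.3-fold lower number from compound 3 to compound 4 (0.97 log units; beyond the scatter)). With cycloheptyl held fixed, the aromatic carbon now shows a readable effect, for methoxy in place of methyl (an at least 83-fold lower number from compound 2 to compound 4 (1.92 log units; beyond the scatter)) and for methoxy in place of hydrogen (an at least 83-fold lower number from compound 1 to compound 4 (1.92 log units; beyond the scatter)). Those two sizes start from limits held by compound 1 and compound 2, not from numbers: (the limit of > 1000 nM in this assay, at which 2 of the 4 values shown sit).

On these data alone, the step from compound 1 to compound 2 cannot be read, so the effect of methyl on an aromatic carbon stays open. Also open, as far as these compounds go, are how cyclohexyl on the saturated ring carbon would read and whether ethoxy or an amine could stand in place of methoxy.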